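Replacing piperidin-1-yl with chloro on the shared core

The compounds below may be only part of what the source reports. "The series", "measured", "known", "first", "only" and "open" are said of these compounds alone.

In an ADME assay on LLC-PK11 cells (Sus scrofa) for cytotoxicity, read by neutral red uptake, with a stated time of 48 h (on this read-out higher numbers stand for weaker inhibition and lower numbers for stronger inhibition), compound 1 `Cc1cc(NCCCCCCNc2ccnc3cc(Cl)ccc23)nc(N2CCN(C)CC2)n1` gives 7200 nM and compound 2 `Cc1cc(NCCCCCCNc2ccnc3cc(Cl)ccc23)nc(N2CCCCC2)n1` gives 6300 nM, so compound 2 stands level with compound 1 within the usual scatter. Compound 3 `Cc1cc(NCCCCCCNc2ccnc3cc(Cl)ccc23)nc(Cl)n1` has not yet been measured. It keeps the rest of compound 2 but carries chloro in place of piperidin-1-yl on an aromatic carbon, between two ring nitrogen atoms: chloro in place of piperidin-1-yl on an aromatic carbon.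

Among the compounds with values here, only one measured step bears on this site, and it is a 1.1-fold lower number from compound 1 to compound 2 (0.06 log units; within the scatter). There, 4-methylpiperazin-1-yl gave way to piperidin-1-yl, so one ring replaced another. In compound 3, a single chlorine with no ring enters instead, which makes that step only a loose guide. It points in neither direction, so no shift beyond the scatter is expected in this assay, although the uncertainty is wide. The expected change is a 1.3-fold higher number from compound 2 to compound 3 (0.10 log units; within the scatter). For compound 3, the estimated value is 8000 nM, with an expected range from 3000 nM to 20000 nM.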

Compound 3, half-maximal inhibitory concentration: 15800 nM
Beside the measured number, compound 3's estimate is 2.0-fold (0.30 log units) below it; measured number inside the range.
By their numbers in this assay, from the lowest: compounds 2 and 1 (each within the scatter of the next); then compound 3.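

In this assay the position between two ring nitrogen atoms now proves able to move the number, with a 2.5-fold higher number from compound 2 to compound 3 (0.40 log units; beyond the scatter) and a 2.2-fold higher number from compound 1 to compound 3 (0.34 log units; beyond the scatter) when chloro takes the place of the ring, and on this read-out a higher number means weaker inhibition. The earlier step swapped one six-membered ring for another and stayed within the scatter, which made the site look indifferent; the new steps show that going from a ring to a single chlorine atom does register, though both are modest and the two ring compounds remain level with each other. Nothing measured here explains why the number rises.

From the compounds shown here alone, what remains open is whether the rise comes with losing the ring or with chlorine itself, a question that a small open-chain amine such as dimethylamino or a lone methoxy group at this position could help to settle. Going by these compounds, it is also open whether another six-membered ring, such as morpholine, would stand level with piperidin-1-yl and 4-methylpiperazin-1-yl.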